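The compounds below may be only part of what the source reports. "The series", "measured", "known", "first", "only" and "open" are said of these compounds alone.

Compound 1, `CN(C)C(=O)c1cc2cnc(Nc3ccc(S(=O)(=O)NCCCN=C=S)cc3)nc2n1C1CCCC1`, was tested in a functional assay on A549 cells (Homo sapiens) for inhibition, read by CCK-8 assay, with a stated time of 72 h, tested at 1 uM (a higher number here means a stronger effect of the compound at the concentration tested, a lower number a weaker effect), where compound 1 gives 58.9%. Compound 2, `CN(C)C(=O)c1cc2cnc(Nc3ccc(S(=O)(=O)NCCCCN=C=S)cc3)nc2n1C1CCCC1`, carries a group of 4 heavy atoms (2 carbon, 1 nitrogen, 1 sulfur; no ring) in place of a group of 3 heavy atoms (1 carbon, 1 nitrogen, 1 sulfur; no ring), on a saturated chain carbon, three bonds along the chain from a sulfonamide nitrogen, and in this assay compound 2 gives 39.4%, so that a number 19.5 percentage points lower from compound 1 to compound 2 (beyond the scatter).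

Compound 3, `CN(C)C(=O)c1cc2cnc(Nc3ccc(C(=O)NCCCCN=C=S)cc3O)nc2n1C1CCCC1`, rests on a different core; the difference between the two cores is not broken down here. In this assay compound 3 gives 30.3%.

Compound 4, `CN(C)C(=O)c1cc2cnc(Nc3ccc(C(=O)NCCCCCN=C=S)cc3O)nc2n1C1CCCC1`, is not yet measured. It differs from compound 3 by a group of 4 heavy atoms (2 carbon, 1 nitrogen, 1 sulfur; no ring) in place of a group of 3 heavy atoms (1 carbon, 1 nitrogen, 1 sulfur; no ring), on a saturated chain carbon, four bonds along the chain from an amide-type nitrogen. This is the same kind of change as that from compound 1 to compound 2, though the place differs: here the chain carbon sits four bonds along the chain from an amide-type nitrogen, there three bonds along the chain from a sulfonamide nitrogen. He expects a step of a number 10.3 percentage points lower from compound 3 to compound 4 (beyond the scatter), because a number 19.5 percentage points lower from compound 1 to compound 2 (beyond the scatter), while the lower value of compound 3 leaves less room to fall. He estimates compound 4 at 20%, between 5% and 38%.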

Compound 4, a percentage reported as inhibition, at one concentration (the size of the read-out at that concentration, not a potency): 23.1%
Compound 4: the middle estimate sits 3.1 percentage points below what was measured; measured number inside the range.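

In this assay, the group of 4 heavy atoms in place of the group of 3 heavy atoms on the core of compound 3 gives a number 7.2 percentage points lower from compound 3 to compound 4 (within the scatter), so this pair alone cannot be told apart. Set beside the step on the core of compound 1, the change does not give clearly different results on the two cores: the same change on two cores in this assay, a number 19.5 percentage points lower (beyond the scatter) from compound 1 to compound 2 and a number 7.2 percentage points lower (within the scatter) from compound 3 to compound 4, 12.3 percentage points apart, within the scatter of two such steps. For the compounds shown here, only the step on the core of compound 1 lies beyond the scatter, and with a single pair on each core, this shows neither that the change carries over at the same size nor that it has no effect on the core of compound 3.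

The compounds shown leave open what a longer chain would give on either core, and what an amine or a carboxylic acid would give at the end of the chain. They also leave open how the sulfonamide and the amide-type link compare on their own, since compound 2 and compound 3 differ in more than one place.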